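From cyclobutyl to isopentyl on the amide-type nitrogen

The source may hold more compounds than are shown below. What is called first, only, known or untested is meant among the compounds shown, and "the series" means these compounds.

In an ADME assay on a cell-free system (plasma, Rattus norvegicus), with a stated time of 60 min (on this read-out lower numbers stand for a less stable compound and higher numbers for a more stable compound), compound 2 `O=C(O)c1cc(-c2cccc(COc3ccc4c(c3)CN(C3CCC3)C4=O)c2)ccc1Cl` gives 100% and compound 1 `O=C(O)c1cc(-c2cccc(COc3ccc4c(c3)CN(Cc3ccc(C(F)(F)F)cc3)C4=O)c2)ccc1Cl` gives 100% as well, so the two stand level. Compound 3 `CC(C)CCN1Cc2cc(OCc3cccc(-c4ccc(Cl)c(C(=O)O)c4)c3)ccc2C1=O` differs from compound 2 by isopentyl in place of cyclobutyl on an amide-type nitrogen in a ring on an amide-type nitrogen in a ring, where isopentyl, which has no ring, takes the place of cyclobutyl. For the measured compounds named here, the only measured step at this nitrogen shows no change at the digits printed from compound 1 to compound 2 (within the scatter) with a much larger group leaving, so no step beyond the scatter is expected in this assay here. The estimated step of a number 2 percentage points lower from compound 2 to compound 3 (within the scatter) is expected to stay within the scatter. Compound 3 is estimated at 98% with a range from 88% to 104% in this measurement.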

Compound 3, percent of the compound remaining: 94%
Estimate against measurement, compound 3: 4 percentage points above; the range from low to high includes it.
By their numbers in this assay, from the lowest: compounds 3, 1 and 2 (each within the scatter of the next).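

In this assay isopentyl in place of cyclobutyl gives a number 6 percentage points lower from compound 2 to compound 3 (within the scatter) and isobutyl in place of 4-(trifluoromethyl)phenyl on a saturated chain carbon bound to the nitrogen gives a number 6 percentage points lower from compound 1 to compound 3 (within the scatter) as the second reading. The amide-type nitrogen has now carried a group with no ring, as well as two groups with a ring, with no step beyond the scatter. Nothing available here offers an explanation for these numbers.

Still open, from the compounds shown here alone, is how this assay responds when this chain carries an ester or an amine, or when it is replaced by a longer chain such as octyl.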